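Removing the Phenyl from a Potent Antiproliferative Compound

This account rests on a few compounds, and the source may have more. Where it says the series, first, only, none or still open, it means among the compounds named here.

Compound 1 `O=C1CS/C(=N/Nc2nncc3ccccc23)N1c1ccccc1`: 3 nM
Compound 2 `S=C(NNc1nncc2ccccc12)Nc1ccccc1`: 95 nM

Both values come from a functional assay on HL-60 cells (Homo sapiens) for antiproliferative activity, read by sulforhodamine B assay, with a stated time of 72 h; on this read-out lower numbers stand for stronger inhibition and higher numbers for weaker inhibition. Compound 1 holds the lower number of the two, and compound 2 stands above it by a gap beyond the scatter. Compound 3 `O=C1CS/C(=N/Nc2nncc3ccccc23)N1` has not yet been measured. It carries hydrogen in place of phenyl on an amide-type nitrogen in a ring. Among the compounds with values here, no measured pair isolates this change, so the size of the step remains a judgement. A step toward weaker inhibition, beyond the scatter, is expected. The expected change is a 17-fold higher number from compound 1 to compound 3 (1.22 log units; beyond the scatter). For compound 3 the estimated value is 50 nM, with a range of 8 nM to 400 nM.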

Compound 3, half-maximal inhibitory concentration: 4 nM
Compound 3: middle estimate off by 13-fold (1.10 log units), on the high side; the whole stated range lies above it.
By their numbers in this assay, from the lowest: compounds 1 and 3 (each within the scatter of the next); then compound 2.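

In this assay the change gives a 1.3-fold higher number from compound 1 to compound 3 (0.12 log units; within the scatter), so hydrogen in place of phenyl on this amide-type nitrogen in a ring leaves the read-out within the usual scatter. The phenyl is therefore not needed at this position for the low number seen with compound 1. Nothing measured here offers a reason for this result.

Going by these compounds, whether other groups at this nitrogen, such as a methyl, a benzyl or a longer chain ending in an amine, would also stay within the scatter of compound 1 remains open. So does whether this tolerance extends to other cell lines.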